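From 4-hydroxyphenyl to 3-hydroxyphenyl on a shared core

The source may report more compounds than this note shows. Statements on the series, on what has been measured and on what is new or still open speak of the compounds shown alone.

Compound 3 (`Oc1ccc(Nc2nc(/C=C/c3cccc(Cl)c3)nc3ccccc23)cc1`) gives 21900 nM in a functional assay on HCT-116 cells (Homo sapiens) for antiproliferative activity, with a stated time of 72 h (a lower number here means a stronger inhibitor, a higher number a weaker inhibitor), and lies within the scatter of both other measured compounds. Compound 1 (`COc1ccc(/C=C/c2nc(Nc3cccc(O)c3)c3ccccc3n2)cc1`) gives 22900 nM in this assay and compound 2 (`O=[N+]([O-])c1cccc(/C=C/c2nc(Nc3cccc(O)c3)c3ccccc3n2)c1`) gives 10900 nM in the same read-out of this assay as well.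

Compound 4 (`Oc1cccc(Nc2nc(/C=C/c3cccc(Cl)c3)nc3ccccc23)c1`) has the same atoms as compound 3, joined differently: 3-hydroxyphenyl in place of 4-hydroxyphenyl on a nitrogen on an aromatic ring.

For the measured compounds named here, no measured pair makes this exact swap. Going by the values given here, the only measured step, a 2.1-fold lower number from compound 1 to compound 2 (0.32 log units; beyond the scatter) (a modest one), changes a group on the double-bonded chain and leaves the hydroxyphenyl alone, so it bears only indirectly. Compounds 1 and 2 already carry 3-hydroxyphenyl, and neither lies beyond the scatter of compound 3 in this assay.

The expected change is a 1.3-fold lower number from compound 3 to compound 4 (0.11 log units; within the scatter) in this assay and is estimated to stay within the scatter. For compound 4 the estimated value is 17000 nM with a range from 8000 nM to 35000 nM in this assay.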

Compound 4, half-maximal inhibitory concentration: > 25000 nM
Compound 4 gave a limit, no number; the forecaster's own chance of this, stated with the estimate: 5%; middle value at least 1.4-fold (0.16 log units) away from the limit.
By their numbers in this assay, from the lowest: compounds 2, 3 and 1 (each within the scatter of the next, the first and the last beyond it). At a limit, above all of these: compound 4.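

Compound 4 stands only as a limit: the limit of > 25000 nM in this assay, at which 1 of the 4 values shown sits. Swapping 4-hydroxyphenyl for 3-hydroxyphenyl on the nitrogen gives an at least 1.1-fold higher number from compound 3 to compound 4 (0.05 log units; that floor lies within the scatter), so this swap shows no clear change, and the same holds for the change on the double-bonded chain in an at least 1.0-fold higher number from compound 1 to compound 4 (0.03 log units; that floor lies within the scatter). For the compounds shown here, with 3-hydroxyphenyl held fixed, chloro in place of nitro on the aromatic carbon gives an at least 2.2-fold higher number from compound 2 to compound 4 (0.36 log units; beyond the scatter), so the only step to compound 4 that clears the scatter comes from the chloro and nitro swap, not the hydroxyphenyl swap.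

From the compounds shown here alone, how far the true value of compound 4 lies past its limit remains open, and with it whether the hydroxyphenyl swap has any real effect in this assay. Also open, going by these compounds, is how a phenyl bearing an amine or a carboxylic acid in place of the hydroxyl would behave on that nitrogen.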